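A few compounds are considered here, and "the series" means these few. Any claim that something is new, unique, unknown or untested is made for them only; others in the source may bear on it.

Measured in an assay on isolated protein (strain albino) for antagonist activity at Voltage-dependent L-type calcium channel subunit alpha-1C (Cavia porcellus); on this read-out higher numbers stand for weaker inhibition and lower numbers for stronger inhibition: compound 1 `CCCOC(=O)C1=C(C)NC(C)=C(C(=O)OCCC)C1c1cnc(SC)n1Nc1ccccc1` gives 2.29 nM; compound 2 `CSc1ncc(C2C(C(=O)OCc3ccccc3)=C(C)NC(C)=C2C(=O)OCc2ccccc2)n1Nc1ccccc1` gives 1.49 nM; compound 3 `CCCOC(=O)C1=C(C)NC(C)=C(C(=O)OC)C1c1cnc(SC)n1Nc1ccccc1` gives 2.4 nM.

Compound 3 carries the highest number of the three, but compound 1 and compound 2 both sit within the scatter of it. The step to compound 4 `COC(=O)C1=C(C)NC(C)=C(C(=O)OCc2ccccc2)C1c1cnc(SC)n1Nc1ccccc1` is phenyl in place of ethyl on a saturated chain carbon bound to an oxygen next to a carbonyl group. Among the compounds with values here, no measured step covers this exchange directly. Within the data shown here, the one step at the same place, a 1.0-fold higher number from compound 1 to compound 3 (0.02 log units; within the scatter), did not move this assay. Compound 1 and compound 2, the dipropyl and dibenzyl esters, give values within the scatter of each other. Compound 4 is therefore expected to give 1.9 nM (range 0.9 nM to 4 nM), a step of a 1.3-fold lower number from compound 3 to compound 4 (0.10 log units; within the scatter) expected to fall within the scatter.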

Compound 4, half-maximal inhibitory concentration: 2.21 nM
Compound 4: the middle estimate sits 1.2-fold (0.07 log units) below what was measured; the range from low to high includes it.
By their numbers in this assay, from the lowest: compounds 2, 4, 1 and 3 (each within the scatter of the next).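

In this assay the benzyloxycarbonyl group in place of propoxycarbonyl, with the methyl ester held constant, gives a 1.1-fold lower number from compound 3 to compound 4 (0.04 log units; within the scatter). Hydrogen in place of phenyl on the saturated chain carbon, with the benzyl ester held constant, gives a 1.5-fold higher number from compound 2 to compound 4 (0.17 log units; within the scatter). Matched steps now show that a six-membered aromatic ring at this place, like the earlier ethyl exchange, leaves the number within the scatter.

From the compounds shown here alone, whether an amine or a carboxylic acid on this chain would move the number stays open. Nothing at hand explains why these exchanges stay within the scatter.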